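This account rests on a few compounds, and the source may have more. Where it says the series, first, only, none or still open, it means among the compounds named here.

Three compounds from one series were tested in a functional assay on HepG2 cells (Homo sapiens) for antiproliferative activity, read by MTT assay, with a stated time of 48 h; on this read-out lower numbers stand for stronger inhibition and higher numbers for weaker inhibition. Compound 1 `COc1ccc(-c2ccc3c(c2)C(=O)C(=O)N3Cc2ccc(C#N)cc2)cc1` gives 1000 nM in this assay. Compound 2 `COc1ccc(-c2ccc3c(c2)C(=O)C(=O)N3Cc2ccc(C(F)(F)F)cc2)cc1` differs from it in a single place, (trifluoromethyl in place of cyano on an aromatic carbon), and in this assay compound 2 gives 380 nM. That one change made a 2.6-fold lower number from compound 1 to compound 2 (0.42 log units; beyond the scatter). Compound 3 `COc1ccc(CN2C(=O)C(=O)c3cc(-c4ccc(C#N)cc4)ccc32)cc1` is built from the same atoms as compound 1, joined differently; the difference between the two cores is not broken down here. In this assay compound 3 gives 890 nM, close to compound 1 and a larger number than compound 2. Compound 4 `COc1ccc(CN2C(=O)C(=O)c3cc(-c4ccc(C(F)(F)F)cc4)ccc32)cc1` has not yet been measured. It stands to compound 3 as compound 2 stands to compound 1: trifluoromethyl in place of cyano on an aromatic carbon, at a place described in the very same words, so this is the same change. Resting on the one earlier example, a 2.6-fold lower number from compound 1 to compound 2 (0.42 log units; beyond the scatter), the expected step is a 2.2-fold lower number from compound 3 to compound 4 (0.35 log units; beyond the scatter), of similar size. On that basis compound 4 is expected to give about 400 nM in this assay, with a likely range from 200 nM to 900 nM.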

Compound 4, half-maximal inhibitory concentration: 820 nM
Estimate against measurement, compound 4: 2.1-fold (0.31 log units) below; the range from low to high includes it.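

On the core of compound 3, putting trifluoromethyl in place of cyano gives a 1.1-fold lower number from compound 3 to compound 4 (0.04 log units; within the scatter), so in this assay this change has no readable effect on that core, although the step on the core of compound 1 lay beyond the scatter. Set side by side, the two steps do not differ by more than ordinary measurement scatter allows: the same change on two cores in this assay, a 2.6-fold lower number (0.42 log units; beyond the scatter) from compound 1 to compound 2 and a 1.1-fold lower number (0.04 log units; within the scatter) from compound 3 to compound 4, 2.4-fold (0.38 log units) apart, within the scatter of two such steps. Going by these compounds alone, the result therefore does not show that the core alters the effect of this change, nor does it show that the effect carries reliably from one core to the other, since each core offers only a single pair and the two steps could reflect either one shared modest effect or two different ones.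

The compounds shown leave open how an amine, a carboxylic acid or a longer chain would behave in place of cyano or trifluoromethyl on either core. They also leave open whether the same change would give a readable step on a third core.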